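Shortening the amide side chain of an indole sulfone

The source may report more compounds than this note shows. Statements on the series, on what has been measured and on what is new or still open speak of the compounds shown alone.

Three compounds share one core and differ only in the group on the amide nitrogen. Compound 1 `Cc1cc(C)cc(S(=O)(=O)c2c(C(=O)NC(C)C(=O)NC(C)c3ccncc3)[nH]c3ccc(Cl)cc23)c1` carries a chain ending in a pyridin-4-yl group; compound 2 `Cc1cc(C)cc(S(=O)(=O)c2c(C(=O)NCC(=O)NC(C)c3ccccc3)[nH]c3ccc(Cl)cc23)c1` has a shorter chain ending in a phenyl group; compound 3 `Cc1cc(C)cc(S(=O)(=O)c2c(C(=O)NC(C)C(=O)NC(C)c3ccccc3F)[nH]c3ccc(Cl)cc23)c1` has the chain of compound 1 ending in a 2-fluorophenyl group. In an ADME assay on MT4 cells (Homo sapiens) for cytotoxicity, read by MTT assay (on this read-out lower numbers stand for higher toxicity in this test and higher numbers for lower toxicity in this test), compound 2 gives 29400 nM, and compound 1 with 21900 nM as well as compound 3 with 15200 nM lie within the scatter of that number. Going by the values given here, the only single-point step, a 1.4-fold lower number from compound 1 to compound 3 (0.16 log units; within the scatter), changed a ring at the chain end and stayed within the scatter.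

Compound 4 `Cc1cc(C)cc(S(=O)(=O)c2c(C(=O)Nc3ccnc(C#N)c3)[nH]c3ccc(Cl)cc23)c1` removes the chain altogether: 2-cyanopyridin-4-yl in place of ((1-phenylethyl)carbamoyl)methyl on an amide-type nitrogen. Among the compounds with values here, no measured step covers a change of this kind, so the step from compound 2 to compound 4 is uncharted, and the measured step offers no direction. For this assay compound 4 is estimated at 24000 nM, with a broad range from 7000 nM to 80000 nM, which would mean an expected step of a 1.2-fold lower number from compound 2 to compound 4 (0.09 log units; within the scatter).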

Compound 4, half-maximal cytotoxic concentration: 6840 nM
For compound 4 the middle estimate is 3.5-fold (0.55 log units) above the measured one; measured number below the stated range.
By their numbers in this assay, from the lowest: compound 4; then compounds 3, 1 and 2 (each within the scatter of the next).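

In this assay, going by these compounds alone, the group on the amide-type nitrogen can move the number: 2-cyanopyridin-4-yl in place of ((1-phenylethyl)carbamoyl)methyl gives a 4.3-fold lower number from compound 2 to compound 4 (0.63 log units; beyond the scatter), a modest step toward higher toxicity in this test, whereas the one earlier step, a change at the chain end, stayed within the scatter. This single swap changes several things at once: the chain with its carbonyl and amide hydrogen leaves, while a ring with a hetero atom and a nitrile enters. Nothing measured here gives a reason for the shift.

The compounds shown leave open whether losing the chain or gaining the 2-cyanopyridin-4-yl group matters more. A plain phenyl or pyridin-4-yl on that amide-type nitrogen would help separate the two.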